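Methyl step from compound 2, working notes

The compounds below may be only part of what the source reports. "The series", "measured", "known", "first", "only" and "open" are said of these compounds alone.

- Compound 1 `COc1ccc(Cn2c(C(=O)O)c(CNCc3cccc(O)c3)c3ccccc32)cc1`: > 50000 nM (a limit)
- Compound 2 `COc1cccc(CNCc2c(C(=O)O)n(Cc3ccc(C)cc3)c3ccccc23)c1`: 21500 nM
- Compound 3 `COc1cccc(CNCc2c(C(=O)O)n(Cc3ccc(O)cc3)c3cc(C(C)C)ccc23)c1`: 7080 nM
- Compound 4 `COc1cccc(CNCc2c(C(=O)O)n(Cc3ccc(C)cc3)c3cc(C)ccc23)c1`: not yet measured

In a functional assay on Bel-7402 cells (Homo sapiens) for antiproliferative activity, read by MTT assay, with a stated time of 72 h (on this read-out higher numbers stand for weaker inhibition and lower numbers for stronger inhibition), compound 2, at 21500 nM, has the higher of the two true numbers. Its nearest neighbour is compound 3, at 7080 nM, and that gap lies beyond the usual scatter. Compound 1 reports only a limit, > 50000 nM.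

Compound 4 follows from compound 2 by one change: methyl in place of hydrogen on an aromatic carbon. Among the measured compounds shown here, no pair of measured compounds differs in one place only, so the series offers no direct guide to the size of this step. In this assay a small shift toward stronger inhibition is expected, quite possibly none beyond the scatter. The estimated step is a 1.4-fold lower number from compound 2 to compound 4 (0.16 log units; within the scatter). For compound 4 the estimated value is 15000 nM, with an expected range of 6500 nM to 35000 nM.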

Compound 4, half-maximal inhibitory concentration: 5670 nM
Beside the measured number, compound 4's estimate is 2.6-fold (0.42 log units) above it; the whole stated range lies above it.
By their numbers in this assay, from the lowest: compounds 4 and 3 (each within the scatter of the next); then compound 2. At a limit, above all of these: compound 1.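

In this assay, methyl in place of hydrogen on an aromatic carbon, meta to a fused ring and para to a fused ring, gives a 3.8-fold lower number from compound 2 to compound 4 (0.58 log units; beyond the scatter), so this position of the shared core responds to the addition of a single carbon. Among the compounds shown here, this is the first comparison in which only one place changes; the earlier compounds differ from one another in more than one place and could not isolate this position. Nothing measured here accounts for the size of this step.

From the compounds shown here alone, whether the step depends on methyl itself remains open: an ethyl group, a methoxy group or a chlorine atom on the same carbon would test this. Going by these compounds, one pair sets no pattern, so whether the step carries over to other members is also open.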